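Pyridin-2-yl in Place of 2-Fluorophenyl on a Ring Nitrogen

The compounds below may be only part of what the source reports. "The series", "measured", "known", "first", "only" and "open" are said of these compounds alone.

Of the compounds shown here, two built on one shared core have been measured in a functional assay on MCF7 cells (Homo sapiens) for antiproliferative activity, read by MTT assay, with a stated time of 72 h; on this read-out higher numbers stand for weaker inhibition and lower numbers for stronger inhibition. Compound 1 `Cc1ccc(N2CCN(C(=S)SCc3ccc4nc(N)nc(N)c4c3)CC2)c(C)c1` gives 3120 nM in this assay, and compound 2 `Nc1nc(N)c2cc(CSC(=S)N3CCN(c4ccccc4F)CC3)ccc2n1` gives 4840 nM. The step of a 1.6-fold higher number from compound 1 to compound 2 (0.19 log units; within the scatter) shows that exchanging one six-membered aromatic ring for another on the amine nitrogen in the ring left the number essentially where it was. Compound 2 holds the highest of the two numbers, but its nearest neighbour, compound 1, sits so close that no real order between them can be claimed.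

Compound 3 `Nc1nc(N)c2cc(CSC(=S)N3CCN(c4ccccn4)CC3)ccc2n1` has not yet been measured. It differs from compound 2 in one place: pyridin-2-yl in place of 2-fluorophenyl on an amine nitrogen in a ring. Among the compounds with values here, no measured step involves a pyridin-2-yl group, so the only guide is the step from compound 1 to compound 2, which was small. On that basis a change no larger than the scatter is expected, in no particular direction, so the estimated step is a 1.0-fold higher number from compound 2 to compound 3 (0.01 log units; within the scatter). Compound 3 is therefore expected to give about 5000 nM in this assay, within a range from 2000 nM to 12000 nM.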

Compound 3, half-maximal inhibitory concentration: 5110 nM
Compound 3: middle estimate off by 1.0-fold (0.01 log units), on the low side; measured number inside the range.
By their numbers in this assay, from the lowest: compounds 1, 2 and 3 (each within the scatter of the next).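

In this assay, within the data shown here, putting pyridin-2-yl in place of 2-fluorophenyl gives a 1.1-fold higher number from compound 2 to compound 3 (0.02 log units; within the scatter), so this is the first sign that a ring nitrogen and a hydrogen-bond acceptor can enter this aromatic ring, on the amine nitrogen in the six-membered non-aromatic ring, with no change that can be told from the scatter. The comparison with the 2,4-dimethylphenyl group points the same way, with a 1.6-fold higher number from compound 1 to compound 3 (0.21 log units; within the scatter), so the three aromatic rings seen at this position, one with two methyl groups, one with a fluorine and one with a ring nitrogen, cannot be separated in this assay. No measurement is available that could explain why these numbers stay so close together.

Going by these compounds, all three groups are six-membered aromatic rings, so it stays open whether a group without such a ring, such as cyclohexyl or a simple methyl, or a longer chain such as benzyl, would move the number beyond the scatter. On these data alone, it also stays open whether an amine or a carboxylic acid carried on the aromatic ring would shift it in either direction.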